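A few compounds are considered here, and "the series" means these few. Any claim that something is new, unique, unknown or untested is made for them only; others in the source may bear on it.

Compound 3 `Cc1nn(-c2ncnc3nc[nH]c23)c2c1C(c1ccc(F)cc1Cl)CC(=O)N2` gives 9 nM in a functional assay on HEK293 cells for agonist activity at G-protein coupled receptor 39 (Homo sapiens), read by scintillation proximity assay and inositol phosphate accumulation, with a stated time of 75 min, in the presence of a further agent that is not named here (on this read-out lower numbers stand for an effect already at smaller amounts and higher numbers for an effect only at larger amounts of compound), the highest of the three numbers recorded. Compound 1 `Cc1nn(-c2ncnc3nc[nH]c23)c2c1C(OC(=O)c1ccc(F)cc1)CC(=O)N2` gives 4 nM in this assay, and compound 2 `Cc1nn(-c2ncnc3nc[nH]c23)c2c1C(OCCc1ccccc1)CC(=O)N2` gives 3 nM there. The step of a 2.3-fold higher number from compound 1 to compound 3 (0.35 log units; beyond the scatter) and the step of a 3.0-fold higher number from compound 2 to compound 3 (0.48 log units; beyond the scatter) both run from an oxygen-linked group on the saturated ring carbon to the directly attached 2-chloro-4-fluorophenyl, and both raise the number beyond the scatter, while the step of a 1.3-fold lower number from compound 1 to compound 2 (0.12 log units; within the scatter) between the two oxygen-linked groups stays within it.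

Compound 4 `Cc1nn(-c2ncnc3nc[nH]c23)c2c1C(OCC(C)C)CC(=O)N2` reverses that direction: isobutoxy in place of 2-chloro-4-fluorophenyl on a saturated ring carbon. Of the measured steps, a 3.0-fold higher number from compound 2 to compound 3 (0.48 log units; beyond the scatter) bears most closely on it, since phenethyloxy and isobutoxy are both alkoxy groups on the same carbon; a 2.3-fold higher number from compound 1 to compound 3 (0.35 log units; beyond the scatter) points the same way. An oxygen-linked group is therefore expected to bring the number back down in this assay, by a step roughly the size of those two in the opposite direction, so compound 4 is expected to show a 2.3-fold lower number from compound 3 to compound 4 (0.35 log units; beyond the scatter). On that basis compound 4 is estimated at 4 nM in this assay, with a range from 1.5 nM to 12 nM.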

Compound 4, half-maximal effective concentration: 4 nM
Beside the measured number, compound 4's estimate shows no gap at the digits printed; the measured number falls inside the stated range.
By their numbers in this assay, from the lowest: compounds 2, 1 and 4 (each within the scatter of the next); then compound 3.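

In this assay, the step of a 2.3-fold lower number from compound 3 to compound 4 (0.35 log units; beyond the scatter) shows that the move from the directly attached 2-chloro-4-fluorophenyl to an oxygen-linked group does not depend on that group carrying a ring, since isobutoxy has none. The steps of a 1.3-fold higher number from compound 2 to compound 4 (0.12 log units; within the scatter) and no change at the digits printed from compound 1 to compound 4 (within the scatter) both stay within the scatter, so at this saturated ring carbon the three oxygen-linked groups, with or without a ring or a carbonyl, cannot be told apart by their numbers. No information is available here on what lies behind this.

The compounds shown leave open whether the oxygen itself matters, as an isobutyl group attached directly to the same ring carbon would test. On these data alone, it also remains open whether an oxygen-linked chain ending in an amine or a carboxylic acid would fit the same picture.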